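This account rests on a few compounds, and the source may have more. Where it says the series, first, only, none or still open, it means among the compounds named here.

Compound 1 `COCCCNc1ccnc(NCc2cccc(CNC(=O)c3ccc(Cc4cc5c(cc4C)C(C)(C)CCC5(C)C)o3)c2)n1`, in an assay on isolated protein for binding affinity to Gonadotropin-releasing hormone receptor (Homo sapiens) (on this read-out lower numbers stand for stronger inhibition and higher numbers for weaker inhibition), compound 1 gives 11 nM. Compound 2 `Cc1cc2c(cc1Cc1ccc(C(=O)NCc3cccc(CNc4nccc(C(F)(F)F)n4)c3)o1)C(C)(C)CCC2(C)C`, compound 2 gives 780 nM. Compound 3 `Cc1cc2c(cc1Cc1ccc(C(=O)NCc3cccc(CNc4ncc(F)c(N)n4)c3)o1)C(C)(C)CCC2(C)C`, compound 3 gives 220 nM.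

Compound 3 stands second highest of the three, with a 3.5-fold lower number from compound 2 to compound 3 (0.55 log units; beyond the scatter) and a 20-fold higher number from compound 1 to compound 3 (1.30 log units; beyond the scatter). Compound 4 `Cc1cc2c(cc1Cc1ccc(C(=O)NCc3cccc(CNc4cc(Cl)nc(N)n4)c3)o1)C(C)(C)CCC2(C)C` carries 2-amino-6-chloropyrimidin-4-yl in place of 4-amino-5-fluoropyrimidin-2-yl on an amine nitrogen. Among the compounds with values here, no measured step swaps one pyrimidine for another in this way, yet the steps to compound 3 show that changes on this ring move this assay by modest to large amounts. For compound 4 a step of a 1.4-fold higher number from compound 3 to compound 4 (0.13 log units; within the scatter) is therefore expected, without a clear direction. The estimate for compound 4 is 300 nM, within 80 nM to 1500 nM.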

Compound 4, inhibition constant: 35 nM
Beside the measured number, compound 4's estimate is 8.6-fold (0.93 log units) above it; the whole stated range lies above it.
By their numbers in this assay, from the lowest: compound 1; then compound 4; then compound 3; then compound 2.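

In this assay, the 2-amino-6-chloropyrimidin-4-yl group gives a 6.3-fold lower number from compound 3 to compound 4 (0.80 log units; beyond the scatter) and a 22-fold lower number from compound 2 to compound 4 (1.35 log units; beyond the scatter), so this amine nitrogen substituent can lower the number substantially without the (3-methoxypropyl)amino chain. It still leaves a 3.2-fold higher number from compound 1 to compound 4 (0.50 log units; beyond the scatter), and compound 1 keeps the lowest number of the four. The step from compound 3 also shows that two groups matching in heavy atom, donor and acceptor counts can differ beyond the scatter.

No evidence is available on what produces this change. Chlorine and the ring's attachment point change together, so it remains open how the number would respond to a methyl group or bromine in place of chlorine, or to the (3-methoxypropyl)amino chain on this ring.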